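The source may hold more compounds than are shown below. What is called first, only, known or untested is meant among the compounds shown, and "the series" means these compounds.

Series notes, measured in a functional assay on Coronary artery (Bos taurus); a lower number here means that less compound is needed, a higher number that more compound is needed for the effect:

- compound 1 `CCCCCCC(=O)N(CCCC/C=C\CCCCCCC(=O)OCCOCCOCCO)C(C)C`: 2900 nM
- compound 2 `CCCCCNC(=O)NCCCC/C=C\CCCCCS(=O)(=O)c1ccccc1O`: 5000 nM

Compound 2 at 5000 nM and compound 1 at 2900 nM lie within the scatter of each other, so this assay does not separate the two. Within the data shown here, compound 2 therefore stands level with the only other measured compound, and the two differ in more than one place.

Compound 3 `CCCCCNC(=O)NCCCC/C=C\CCCCCCc1noc(=S)[nH]1` is not yet measured and derives from compound 2 by a single change: a group of 7 heavy atoms (3 carbon, 2 nitrogen, 1 oxygen, 1 sulfur; one five-membered aromatic ring with 3 hetero atoms) in place of a group of 10 heavy atoms (6 carbon, 3 oxygen, 1 sulfur; one six-membered aromatic ring of carbon only), on a saturated chain carbon, five bonds along the chain from a double-bonded chain carbon. The (2-hydroxyphenyl)sulfonyl group leaves, and the new group with its five-membered aromatic ring with 3 hetero atoms sits on a saturated chain carbon, five bonds along the chain from a double-bonded chain carbon.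

Among the measured compounds shown here, no measured step covers such a change, so the direction is a judgement and not a reading. A modest move towards a lower number is expected, with an estimated size of a 2.5-fold lower number from compound 2 to compound 3 (0.40 log units; beyond the scatter). For the measured compounds named here, the range stays wide, since only two measured values anchor it. For compound 3 the estimated value is 2000 nM, with an expected range from 400 nM to 8000 nM.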

Compound 3, half-maximal effective concentration: 3300 nM
Beside the measured number, compound 3's estimate is 1.7-fold (0.22 log units) below it; low and high end bracket the measured number.
By their numbers in this assay, from the lowest: compounds 1, 3 and 2 (each within the scatter of the next).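

In this assay, placing the group of 7 heavy atoms with its five-membered aromatic ring on the saturated chain carbon, in place of (2-hydroxyphenyl)sulfonyl, gives a 1.5-fold lower number from compound 2 to compound 3 (0.18 log units; within the scatter), a step within the scatter. Among these compounds, this is the only step that isolates this position, and it shows that the assay does not separate these two groups, although one has a six-membered aromatic ring of carbon only and the other a five-membered aromatic ring with 3 hetero atoms. No supporting data are available to account for this result.

As far as these compounds go, it remains open whether a carboxylic acid or a tetrazole at this saturated chain carbon, or a longer chain leading to the five-membered aromatic ring, would give a step beyond the scatter from compound 2 in this assay. Among the compounds shown here, the only step at this position lies within the scatter, and a single step establishes no trend for the groups that can sit there.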